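Butyl for isopropyl on the chain of compound 2

This account rests on a few compounds, and the source may have more. Where it says the series, first, only, none or still open, it means among the compounds named here.

In a functional assay on NCI-H460 cells (Homo sapiens) for antiproliferative activity, read by MTT assay, with a stated time of 48 h (a higher number here means a weaker inhibitor, a lower number a stronger inhibitor), compound 1 (`CCCCCC1(O)C(=O)Nc2ccc(Nc3ccc(C)cc3)cc21`) gives > 100000 nM as its reading, which is a limit and not a number. Among the measured compounds shown here, compound 2 (`Cc1ccc(Nc2ccc3c(c2)C(O)(CCC(C)C)C(=O)N3)cc1`) gives 22700 nM as the only number so far. For the measured compounds named here, the one measured step is an at least 4.4-fold lower number from compound 1 to compound 2 (0.64 log units; beyond the scatter) and it came with isopropyl in place of propyl. Compound 3 (`CCCCCCC1(O)C(=O)Nc2ccc(Nc3ccc(C)cc3)cc21`) carries butyl in place of isopropyl on a saturated chain carbon, two bonds along the chain from a saturated ring carbon. Isopropyl leaves here, so the gain seen in an at least 4.4-fold lower number from compound 1 to compound 2 (0.64 log units; beyond the scatter) may be lost, and a higher number is expected in this assay as a result. The expected step is a 2.0-fold higher number from compound 2 to compound 3 (0.30 log units; within the scatter) in size. For compound 3 the estimate is 45000 nM with an estimated range of 15000 nM to 100000 nM in this assay.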

Compound 3, half-maximal inhibitory concentration: > 100000 nM
Compound 3: only a limit was reported; the forecaster's own chance of this, stated with the estimate: 40%; middle value at least 2.2-fold (0.34 log units) away from the limit.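

In this assay, the change from isopropyl to butyl gives an at least 4.4-fold higher number from compound 2 to compound 3 (0.64 log units; beyond the scatter), so the number seen with compound 2 is not kept when butyl takes the place of isopropyl on this saturated chain carbon. Of isopropyl, propyl and butyl at this place, only isopropyl gives a readable number, and the extra carbon of butyl does not bring one back. The step from compound 1 to compound 3 cannot be read, as both readings are limits: the limit of > 100000 nM in this assay, at which 2 of the 3 values shown sit.

Going by these compounds, it remains open how far the readings of compound 1 and compound 3 lie beyond that limit. On these data alone, it also remains open whether a tert-butyl or cyclopropyl group, or an amine on this chain, would give a lower number than isopropyl.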